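This account rests on a few compounds, and the source may have more. Where it says the series, first, only, none or still open, it means among the compounds named here.

In an ADME assay on BSC cells (Cercopithecidae) for cytotoxicity (a higher number here means a weaker inhibitor, a lower number a stronger inhibitor), the measured compounds stand as follows.
Compound 1, `Nc1ncnc2c1ccn2COC(CO)CO`: > 100000 nM.
Compound 2, `CCNc1ncnc2c1c(Cl)cn2COC(CO)CO`: > 100000 nM.

The value of compound 1 is a limit of the assay, not a measured number. The value of compound 2 is likewise a limit, so compound 2 stands at the limit of > 100000 nM in this assay, at which 2 of the 2 values shown sit. Compound 3, `Nc1ncnc2c1c(Cl)cn2COC(CO)CO`, differs from compound 2 by hydrogen in place of ethyl on a nitrogen on an aromatic ring. Among the compounds with values here, no measured pair shows this change, so the expectation rests on the two limits alone. The step is expected to be a step that the limit leaves unreadable from compound 2 to compound 3, within the scatter. Compound 3 is estimated at 150000 nM, between 50000 nM and 500000 nM, most likely reported again as a limit.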

Compound 3, half-maximal inhibitory concentration: > 100000 nM
Compound 3 gave a limit, no number; the forecaster's own chance of this, stated with the estimate: 85%; the middle value lies beyond the limit too.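

No step can be read among compound 1, compound 2 and compound 3 in this assay, because each value is a limit, not a number: the limit of > 100000 nM in this assay, at which 3 of the 3 values shown sit.

From the compounds shown here alone, what ethylamino to amino or chloro in place of hydrogen does to the read-out stays open.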